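This account rests on a few compounds, and the source may have more. Where it says the series, first, only, none or still open, it means among the compounds named here.

In a functional assay on the whole organism with Rattus norvegicus as the target (a lower number here means that less compound is needed, a higher number that more compound is needed for the effect), compound 1 (`CCCOc1ccccc1-c1ncc(-c2nn[nH]n2)c(O)n1`) gives 0.04 mg/kg and compound 2 (`CC(C)Oc1ccccc1-c1ncc(-c2nn[nH]n2)c(O)n1`) gives 0.04 mg/kg while compound 3 (`CCCCOc1ccccc1-c1ncc(-c2nn[nH]n2)c(O)n1`) gives 0.07 mg/kg and so stands within the scatter of both. Compound 4 (`CCC(C)Oc1ccccc1-c1ncc(-c2nn[nH]n2)c(O)n1`) carries sec-butyl in place of butyl on an oxygen on an aromatic ring. The nearest parallel among the measured compounds is isopropyl in place of propyl (no change at the digits printed from compound 1 to compound 2 (within the scatter)). The other two steps, butyl in place of isopropyl (a 1.8-fold higher number from compound 2 to compound 3 (0.24 log units; within the scatter)) and the added methyl that turns propyl into butyl (a 1.8-fold higher number from compound 1 to compound 3 (0.24 log units; within the scatter)), are also small. No step beyond the scatter is therefore expected in this assay in either direction. The expected step is small (a 1.4-fold lower number from compound 3 to compound 4 (0.15 log units; within the scatter)). For compound 4 the estimated dose is 0.05 mg/kg (expected range 0.025 mg/kg to 0.1 mg/kg).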

Compound 4, dose for 50% inhibition: 0.05 mg/kg
The estimate for compound 4 equals the measured number at the digits printed; low and high end bracket the measured number.
By their numbers in this assay, from the lowest: compounds 1, 2, 4 and 3 (each within the scatter of the next).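

On the oxygen on the aromatic ring, sec-butyl in place of butyl gives a 1.4-fold lower number from compound 3 to compound 4 (0.15 log units; within the scatter) in this assay, so branching at the carbon bound to that oxygen is tolerated with sec-butyl as well as with isopropyl. An added methyl on propyl at that carbon gives a 1.3-fold higher number from compound 1 to compound 4 (0.10 log units; within the scatter), and one on the end of isopropyl gives a 1.3-fold higher number from compound 2 to compound 4 (0.10 log units; within the scatter), so neither addition moves the dose beyond the scatter. The same methyl addition, read on two different chains, also agrees: the same change on two cores in this assay, a 1.8-fold higher number (0.24 log units; within the scatter) from compound 1 to compound 3 and a 1.3-fold higher number (0.10 log units; within the scatter) from compound 2 to compound 4, 1.4-fold (0.15 log units) apart, within the scatter of two such steps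

All four groups here are small saturated chains. On these data alone, whether a longer chain, a benzyl group or a chain ending in an amine on this oxygen would keep the dose in this range remains open.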